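The source may hold more compounds than are shown below. What is called first, only, known or untested is meant among the compounds shown, and "the series" means these compounds.

Measured so far:
Compound 1, `CC(C)(N)C(=O)N[C@H](COCc1ccccc1Cl)c1nnnn1CCOC(=O)NCCCCO`: 0.45 nM
Compound 2, `CC(C)(N)C(=O)N[C@H](COCc1cccc(Cl)c1)c1nnnn1CCOC(=O)NCCCCO`: 1.6 nM
Compound 3, `CC(C)(N)C(=O)N[C@H](COCc1ccc(OC(F)(F)F)cc1)c1nnnn1CCOC(=O)NCCCCO`: 33.2 nM

In a functional assay on cells for inhibition of growth hormone secretagogue receptor type 1 (Homo sapiens), read by FLIPR and calcium flux (on this read-out lower numbers stand for an effect already at smaller amounts and higher numbers for an effect only at larger amounts of compound), compound 1 gives 0.45 nM, the lowest of the three numbers. Its nearest neighbour is compound 2, with a 3.6-fold higher number from compound 1 to compound 2 (0.55 log units; beyond the scatter); the furthest is compound 3, with a 74-fold higher number from compound 1 to compound 3 (1.87 log units; beyond the scatter). Between the two chlorophenyl variants and the trifluoromethoxy variant the gap is also clear, a 21-fold higher number from compound 2 to compound 3 (1.32 log units; beyond the scatter). All three compounds share the same core and differ only in the group on the saturated chain carbon bound to an oxygen on a saturated carbon.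

Compound 4, `CC(C)(N)C(=O)N[C@H](COCC1CCCCC1)c1nnnn1CCOC(=O)NCCCCO`, changes this group once more: cyclohexyl in place of 2-chlorophenyl on a saturated chain carbon bound to an oxygen on a saturated carbon. Among the compounds with values here, no measured step exchanges the aromatic ring at this place for a saturated one, so the bearing of the known steps is indirect. What they do show is that every departure from 2-chlorophenyl so far has raised the number, by a modest amount in the step from compound 1 to compound 2 and by a large amount in the step from compound 1 to compound 3. A higher number for compound 4 is therefore expected, with the size uncertain and set between those two steps. Compound 4 is estimated at 5 nM, with a range from 1 nM to 30 nM. This estimate means an expected step of an 11-fold higher number from compound 1 to compound 4 (1.05 log units; beyond the scatter).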

Compound 4, half-maximal effective concentration: 1.66 nM
Compound 4: the middle estimate sits 3.0-fold (0.48 log units) above what was measured; low and high end bracket the measured number.
By their numbers in this assay, from the lowest: compound 1; then compounds 2 and 4 (each within the scatter of the next); then compound 3.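

In this assay an aromatic ring proves not to be essential at this place: the saturated cyclohexyl group gives a 3.7-fold higher number from compound 1 to compound 4 (0.57 log units; beyond the scatter) and, against the other chlorine-bearing ring, a 1.0-fold higher number from compound 2 to compound 4 (0.02 log units; within the scatter), so compound 4 matches compound 2 and stays close to compound 1 without any chlorine. Within the data shown here, the same change gives a 20-fold lower number from compound 3 to compound 4 (1.30 log units; beyond the scatter), which marks the 4-(trifluoromethoxy)phenyl group of compound 3 as the one group of the four with a far higher number, and shows that numbers this low at this place are not limited to chlorophenyl groups. Nothing available here accounts for these differences.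

The step from 2-chlorophenyl to cyclohexyl removes the chlorine and the aromatic ring together, so the compounds shown cannot divide its size between the two, and a plain phenyl group or a chlorine-bearing cyclohexyl group would be needed to separate them. As far as these compounds go, it also stays open how far this place tolerates groups other than carbon rings, such as a longer open chain, or a cyclohexyl group carrying an amine or a carboxylic acid.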